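This account rests on a few compounds, and the source may have more. Where it says the series, first, only, none or still open, it means among the compounds named here.

In a toxicity assay on NIH3T3 cells (Mus musculus) for cytotoxicity, read by resazurin assay (a lower number here means that less compound is needed, a higher number that more compound is needed for the effect), compound 1 `Nc1cc(-c2ccccc2)ccc1Cn1cncc1CNc1ccc(-c2cncs2)c(-c2ccccc2)c1` gives > 1000 nM, which is a limit of the assay rather than a number. Compound 3 `c1ccc(-c2ccc(Cn3cncc3CNc3ccc(-c4cncs4)c(-c4ccccc4)c3)cc2)cc1` gives > 1000 nM, also a limit. Compound 2 `CC(C)c1ccc(Cn2cncc2CNc2ccc(-c3nc4ccccc4s3)c(-c3ccccc3)c2)cc1`, which already carries the 1,3-benzothiazol-2-yl group, gives > 1000 nM, again a limit. Within the data shown here, the only measured change of a single group, a step that the two limits leave unreadable from compound 1 to compound 3, cannot be sized, because of the limit of > 1000 nM in this assay, at which 3 of the 3 values shown sit. Compound 4 `Nc1cc(-c2ccccc2)ccc1Cn1cncc1CNc1ccc(-c2nc3ccccc3s2)c(-c2ccccc2)c1` differs from compound 1 by 1,3-benzothiazol-2-yl in place of 1,3-thiazol-5-yl on an aromatic carbon. Among the measured compounds shown here, no measured step bears on this change; what compound 2 shows is that the entering group sits in a compound at the same limit. Compound 4 is therefore expected to stay at the limit as well, with an estimated step that the limit leaves unreadable from compound 1 to compound 4 of no readable size. Compound 4 is estimated at 2500 nM, between 800 nM and 10000 nM.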

Compound 4, half-maximal effective concentration: > 1000 nM
Compound 4: a limit, no number (the forecaster's own chance of this, stated with the estimate: 80%); the middle value does not contradict the limit.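

The step between compound 1 and compound 4 cannot be read, as both compounds give only a limit and no number: the limit of > 1000 nM in this assay, at which 4 of the 4 values shown sit. The compounds shown leave open how far any of these changes moves the value in this assay, since none of them has a value beyond a limit.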